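The compounds below may be only part of what the source reports. "The series", "measured", "known", "first", "only" and "open" are said of these compounds alone.

Going by the values given here, in a functional assay on HCC827 cells (Homo sapiens) for antiproliferative activity, read by MTT assay, with a stated time of 72 h (a lower number here means a stronger inhibitor, a higher number a weaker inhibitor), compound 2 `CN1CCN(c2ccc(Nc3ncc4nc(Nc5ccc(F)cc5)n(-c5cccc(NC(=O)CO)c5)c4n3)cc2)CC1` gives 7.5 nM and stands as the higher of the two numbers so far. Compound 1 `CN1CCN(c2ccc(Nc3ncc4nc(Nc5ccc(F)cc5)n([C@H]5CCCN(C(=O)CO)C5)c4n3)cc2)CC1` gives 1.8 nM in this assay, and the step of a 4.2-fold higher number from compound 1 to compound 2 (0.62 log units; beyond the scatter) is the only one measured. Compound 3 `CN1CCN(c2ccc(Nc3ncc4nc(Nc5ccc(F)cc5)n([C@H]5CCN(C(=O)OC(C)(C)C)C5)c4n3)cc2)CC1` differs from compound 2 by 1-(tert-butoxycarbonyl)pyrrolidin-3-yl in place of 3-(((hydroxymethyl)carbonyl)amino)phenyl on an aromatic nitrogen. That single step bears on the change, since both swap the whole group on that aromatic nitrogen; it was modest, and the incoming five-membered non-aromatic ring is nearer in kind to the 1-((hydroxymethyl)carbonyl)piperidin-3-yl of compound 1 than to the aromatic group of compound 2. A modest step toward a lower number is therefore expected a 2.5-fold lower number from compound 2 to compound 3 (0.40 log units; beyond the scatter). Compound 3 is estimated at 3 nM with a range from 1 nM to 10 nM.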

Compound 3, half-maximal inhibitory concentration: 580 nM
Compound 3: middle estimate off by 190-fold (2.29 log units), on the low side, and the stated range ends below it.
By their numbers in this assay, from the lowest: compound 1; then compound 2; then compound 3.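

In this assay, 1-(tert-butoxycarbonyl)pyrrolidin-3-yl in place of 1-((hydroxymethyl)carbonyl)piperidin-3-yl on the aromatic nitrogen gives a 320-fold higher number from compound 1 to compound 3 (2.51 log units; beyond the scatter), so a non-aromatic ring at this position does not by itself preserve a low number. The aromatic group fares far better, with the change to the pyrrolidine giving a 77-fold higher number from compound 2 to compound 3 (1.89 log units; beyond the scatter). No measurement available here explains this loss.

Ring size and the nitrogen substituent change together, so their separate contributions remain unresolved. A pyrrolidin-3-yl carrying the (hydroxymethyl)carbonyl group, or a piperidin-3-yl carrying tert-butoxycarbonyl, would separate them.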